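A shorter hydroxycarbamoyl chain after a level pair

This account rests on a few compounds, and the source may have more. Where it says the series, first, only, none or still open, it means among the compounds named here.

Among the compounds with values here, in a functional assay on HEL cells (Homo sapiens) for inhibition (on this read-out lower numbers stand for stronger inhibition and higher numbers for weaker inhibition), compound 1 `CC(C)c1cc(-c2n[nH]c(=O)n2-c2ccc(C(=O)NCCCCCCC(=O)NO)cc2)c(O)cc1O` gives 4600 nM, and compound 2 `CC(C)c1cc(-c2n[nH]c(=O)n2-c2ccc(C(=O)NCCCCCCCC(=O)NO)cc2)c(O)cc1O` gives 4600 nM, so compound 2 stands level with compound 1 on the numbers so far. Compound 3 `CC(C)c1cc(-c2n[nH]c(=O)n2-c2ccc(C(=O)NCCCCCC(=O)NO)cc2)c(O)cc1O` has not yet been measured. It differs from compound 2 as follows: hydroxycarbamoyl in place of 2-(hydroxycarbamoyl)ethyl on a saturated chain carbon, five bonds along the chain from an amide-type nitrogen. In short, hydroxycarbamoyl stands in place of 2-(hydroxycarbamoyl)ethyl on a saturated chain carbon, five bonds along the chain from an amide-type nitrogen.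

Within the data shown here, one measured step bears on this change. The step of no change at the digits printed from compound 1 to compound 2 (within the scatter) came with (hydroxycarbamoyl)methyl in place of hydroxycarbamoyl on the same chain. That single step shows a flat stretch, but compound 3 lies outside the pair of chains measured so far, so the evidence for it is thin and gives no direction. No shift beyond the scatter is therefore expected in this assay, though the range is kept wide. The expected change is a 1.1-fold higher number from compound 2 to compound 3 (0.04 log units; within the scatter). For compound 3 the estimated value is 5000 nM, with an expected range of 2300 nM to 11000 nM.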

Compound 3, half-maximal inhibitory concentration: 4600 nM
Beside the measured number, compound 3's estimate is 1.1-fold (0.04 log units) above it; measured number inside the range.
By their numbers in this assay, from the lowest: compounds 1, 2 and 3 (each within the scatter of the next).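

In this assay, hydroxycarbamoyl in place of 2-(hydroxycarbamoyl)ethyl, on a saturated chain carbon five bonds along the chain from an amide-type nitrogen, gives no change at the digits printed from compound 2 to compound 3 (within the scatter), so the flat stretch seen earlier for a single pair now also holds for a larger change at this position. Hydroxycarbamoyl in place of (hydroxycarbamoyl)methyl at the same place gives no change at the digits printed from compound 1 to compound 3 (within the scatter), which leaves all three chain lengths shown level in this assay, with no compound among them going against that. No supporting information is available that could account for this flat result.

The compounds shown leave open how far this flat stretch runs, since a longer chain or a still shorter one could depart from these values in this assay. All three compounds also end in the same hydroxycarbamoyl group, so they cannot show what this read-out would do if a carboxylic acid or an amine stood at the end of the chain instead.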